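Swapping one open-chain group on an amine nitrogen

The source may report more compounds than this note shows. Statements on the series, on what has been measured and on what is new or still open speak of the compounds shown alone.

compound 1 `CCOC(=O)C1=C(N/C=N/c2cccnc2Cl)Nc2[nH]nc(C)c2C1c1ccc(N(C)C)cc1` - 4630 nM
compound 2 `CCOC(=O)C1=C(N/N=C(\C#N)C(N)=O)Nc2[nH]nc(C)c2C1c1ccc(N(C)C)cc1` - 47300 nM

Both values come from a functional assay on HeLa cells (Homo sapiens) for inhibition, read by MTT assay, with a stated time of 48 h (a lower number here means a stronger inhibitor, a higher number a weaker inhibitor), and compound 2 gives the higher number of the two at 47300 nM with compound 1 as its nearest neighbour. Compound 3 `CCOC(=O)C1=C(NN=C(C#N)C#N)Nc2[nH]nc(C)c2C1c1ccc(N(C)C)cc1` carries a group of 6 heavy atoms (3 carbon, 3 nitrogen; no ring) in place of a group of 7 heavy atoms (3 carbon, 3 nitrogen, 1 oxygen; no ring), on an amine nitrogen and, like compound 2, has no ring in that group. Going by the values given here, the only measured step that bears on this is a 10-fold higher number from compound 1 to compound 2 (1.01 log units; beyond the scatter) and it was large, but it took out a group with a six-membered aromatic ring. The present change swaps one open-chain group for another, so no step beyond the scatter is expected in this assay in either direction. The estimated move is a 1.2-fold lower number from compound 2 to compound 3 (0.07 log units; within the scatter) on present evidence. Compound 3 is estimated at 40000 nM as a middle value, with 12000 nM to 100000 nM as its expected range.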

Compound 3, half-maximal inhibitory concentration: 15200 nM
The estimate for compound 3 lay 2.6-fold (0.42 log units) above the measured number; the range from low to high includes it.
By their numbers in this assay, from the lowest: compound 1; then compound 3; then compound 2.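

In this assay, the position on the amine nitrogen responds even when one open-chain group replaces another: replacing the amide-bearing group with the group bearing a second nitrile gives a 3.1-fold lower number from compound 2 to compound 3 (0.49 log units; beyond the scatter). The group with the six-membered aromatic ring still gives the lowest number of the three, with a 3.3-fold higher number from compound 1 to compound 3 (0.52 log units; beyond the scatter), so the new group recovers only part of the loss seen with compound 2. No measurement available here accounts for either step.

As far as these compounds go, it remains open whether the lower number of compound 1 depends on its chlorine, its ring nitrogen or the aromatic ring itself, which a plain phenyl group on the same amine nitrogen could help to separate. Also open, from the compounds shown here alone, is where a carboxylic acid in place of the amide of compound 2 would fall.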